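The compounds below may be only part of what the source reports. "The series", "measured", "known", "first", "only" and "open" are said of these compounds alone.

For the measured compounds named here, in a functional assay on HepG2 cells (Homo sapiens) for cytotoxicity, read by MTT assay, with a stated time of 48 h (on this read-out lower numbers stand for stronger inhibition and higher numbers for weaker inhibition), compound 1 (`CC(=O)Oc1ccccc1C1CC(C)=NN1C(=O)CN(C(C)C)C(C)C`) gives 34100 nM and compound 2 (`CC(=O)Oc1ccccc1C1CC(C)=NN1C(=O)CN1CCC(C(C)=O)CC1`) gives 7800 nM, so compound 2 holds the lower of the two numbers so far. Compound 3 (`CC(=O)Oc1ccccc1C1CC(C)=NN1C(=O)CCl`) has chloro in place of 4-acetylpiperidin-1-yl on a saturated chain carbon bound to a carbonyl carbon. Going by the values given here, one measured step bears on this place, the replacement of diisopropylamino by 4-acetylpiperidin-1-yl: a 4.4-fold lower number from compound 1 to compound 2 (0.64 log units; beyond the scatter), modest but beyond the scatter. Among the compounds with values here, no measured compound carries chloro here, so this single step is the only guide to size, and it does not settle direction. A modest move toward a higher number is expected in this assay. The expected change is a 2.6-fold higher number from compound 2 to compound 3 (0.41 log units; beyond the scatter). For compound 3 the estimated value is 20000 nM, with an expected range of 6000 nM to 60000 nM.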

Compound 3, half-maximal inhibitory concentration: 2520 nM
Estimate against measurement, compound 3: 7.9-fold (0.90 log units) above; the measured number lies below the stated range.
By their numbers in this assay, from the lowest: compound 3; then compound 2; then compound 1.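

In this assay, for the compounds shown here, an amine on the saturated chain carbon bound to a carbonyl carbon is not needed for the lowest number so far: a 3.1-fold lower number from compound 2 to compound 3 (0.49 log units; beyond the scatter), and the span widens to a 14-fold lower number from compound 1 to compound 3 (1.13 log units; beyond the scatter). Both amine-bearing compounds therefore stand above the chloro compound, and the larger of the two steps is the one from diisopropylamino. Nothing available here accounts for this order.

Open, from the compounds shown here alone, is whether the low number belongs to chloro in particular or would also appear with bromo or a hydroxyl group on this carbon. Also open, going by these compounds, is whether an unsubstituted piperidine or a morpholine would stand with compound 2, or whether the acetyl group of 4-acetylpiperidin-1-yl contributes to its place among the amines.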